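From allyl to 3-hydroxypropyl on a shared core

A few compounds are considered here, and "the series" means these few. Any claim that something is new, unique, unknown or untested is made for them only; others in the source may bear on it.

In a functional assay on A2780 cells (Homo sapiens) for antiproliferative activity, read by sulforhodamine B assay, with a stated time of 48 h (on this read-out higher numbers stand for weaker inhibition of growth and lower numbers for stronger inhibition of growth), three compounds sharing one core have been tested so far. Compound 1 `CC(C)(C)[Si](C)(C)O[C@H]1CCCO[C@@H]1CO` gives > 100000 nM as a limit of the assay and not a number. Compound 2 `CC(C)(C)[Si](C)(C)O[C@@H]1CCCO[C@@H]1COCC(=O)OCc1ccccc1` gives 28000 nM as a measured number. Compound 3 `C=CCOC[C@H]1OCCC[C@H]1O[Si](C)(C)C(C)(C)C` gives 15000 nM and so stands within the scatter of compound 2.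

Compound 4 `CC(C)(C)[Si](C)(C)O[C@@H]1CCCO[C@@H]1COCCCO` is still unmeasured. It carries 2-hydroxyethyl in place of vinyl on a saturated chain carbon bound to an oxygen on a saturated carbon, which turns allyl into 3-hydroxypropyl (2-hydroxyethyl in place of vinyl on a saturated chain carbon bound to an oxygen on a saturated carbon). Going by the values given here, no measured pair shows this change directly, so any forecast is rough. Compound 1 also carries a free hydroxyl and gives > 100000 nM as a limit, so a move toward weaker inhibition is expected. The expected step of a 3.0-fold higher number from compound 3 to compound 4 (0.48 log units; beyond the scatter) is modest and may lie only a little beyond the scatter. For compound 4 the estimate is 45000 nM with an expected range from 18000 nM to 100000 nM for a later measurement to test.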

Compound 4, concentration for 50% growth inhibition: > 100000 nM
Compound 4 was reported as a limit; the forecaster's own chance of this, stated with the estimate: 25%; middle value at least 2.2-fold (0.34 log units) away from the limit.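

In this assay, replacing allyl with 3-hydroxypropyl gives an at least 6.6-fold higher number from compound 3 to compound 4 (0.82 log units; beyond the scatter), so this position on the chain does not tolerate every change without a clear loss of growth inhibition. Compound 4 gives > 100000 nM, which is a limit of the assay and not a number, so the step has a lower bound but no known full size: the limit of > 100000 nM in this assay, at which 2 of the 4 values shown sit.

Among the four compounds shown, the two with a free hydroxyl, compound 1 and compound 4, are the two at this limit, and no compound here goes against that, although four compounds are a small set.

The change removes a double bond and adds a hydroxyl together, and the compounds shown do not separate the two; a plain propyl chain would. On these data alone, what an amine or a carboxylic acid in place of the hydroxyl would do also stays open.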